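Chloro in place of fluoro on a urea series

The source may report more compounds than this note shows. Statements on the series, on what has been measured and on what is new or still open speak of the compounds shown alone.

Compound 1, `CC1(C)CC(NC(=O)Nc2ccccc2)c2cc(F)ccc2O1`, is measured in a functional assay (aorta) with Rattus norvegicus as the target (on this read-out higher numbers stand for an effect only at larger amounts of compound and lower numbers for an effect already at smaller amounts), and gives 17100 nM. Compound 2, `CC1(C)CC(NC(=O)Nc2ccccc2)c2cc(Cl)ccc2O1`, differs from it by chloro in place of fluoro on an aromatic carbon, and in this assay compound 2 gives 7800 nM. The step of a 2.2-fold lower number from compound 1 to compound 2 (0.34 log units; beyond the scatter) is therefore a modest gain.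

Compound 3, `COc1cccc(NC(=O)NC2CC(C)(C)Oc3ccc(F)cc32)c1`, differs from compound 1 by methoxy in place of hydrogen on an aromatic carbon. In this assay compound 3 gives only a limit, > 10000 nM, so the step that the limit leaves unreadable from compound 1 to compound 3 cannot be read; this is because of the limit of > 10000 nM in this assay, at which 1 of the 3 values shown sits.

Compound 4, `COc1cccc(NC(=O)NC2CC(C)(C)Oc3ccc(Cl)cc32)c1`, has not been measured. It differs from compound 3 by chloro in place of fluoro on an aromatic carbon, which is the same change as from compound 1 to compound 2. The two cores differ by methoxy in place of hydrogen on an aromatic carbon.

For compound 4 in this assay the expected step is a step that the limit leaves unreadable from compound 3 to compound 4, resting on the earlier step of a 2.2-fold lower number from compound 1 to compound 2 (0.34 log units; beyond the scatter) and on the limit for compound 3 of > 10000 nM. The estimate for compound 4 is 12000 nM, within 4000 nM to 40000 nM, and a limit rather than a number is quite likely.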

Compound 4, half-maximal effective concentration: > 10000 nM
Compound 4 gave a limit, no number; the forecaster's own chance of this, stated with the estimate: 55%; the middle value is on the limit's open side.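

The step from compound 3 to compound 4 is the same chloro in place of fluoro, but it cannot be read, because each of the two compounds gives a limit and not a number: the limit of > 10000 nM in this assay, at which 2 of the 4 values shown sit.

In the core of compound 1, the change gave a 2.2-fold lower number from compound 1 to compound 2 (0.34 log units; beyond the scatter), and in this assay the methoxy core neither confirms nor contradicts that gain, so nothing can be said about whether the change carries over. For the compounds shown here, the one new step that can be read, for methoxy in place of hydrogen, is an at least 1.2-fold higher number from compound 2 to compound 4 (0.10 log units; that floor lies within the scatter); this shows no real difference on its own, though the true step could be larger.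

Going by these compounds, it remains open whether chloro in place of fluoro would give a similar step on a core that stays within the measurable range of the assay. Also open, on these data alone, is how bromo would read in place of chloro on the same aromatic carbon, or how an amine would read in place of the methoxy.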